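The source may report more compounds than this note shows. Statements on the series, on what has been measured and on what is new or still open speak of the compounds shown alone.

Measured compounds:
- compound 1, `Cc1ccc(C(CCN(C)C)NC(=O)CCc2ccc(C(F)(F)F)cc2)cc1`: 60%
- compound 2, `CN(C)CCC(NC(=O)CCc1ccccc1)c1ccc(Cl)cc1`: 139%
- compound 3, `CN(C)CCC(NC(=O)CCc1ccc(C(F)(F)F)cc1)c1ccc2ccccc2c1`: 75%

All three were tested in a functional assay on NIH3T3 cells for agonist activity at Urotensin-2 receptor (Homo sapiens), with a stated time of 5 days; a lower number here means a smaller maximal response, a higher number a larger maximal response. Among these numbers compound 3 stands second highest: its nearest neighbour is compound 1, whose value is lower beyond the scatter, while compound 2 lies far above it, also beyond the scatter.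

The new compound is compound 4, `CN(C)CCC(NC(=O)CCc1ccc(C(F)(F)F)cc1)c1ccc(Cl)cc1`. It differs from compound 3 in one place: 4-chlorophenyl in place of naphthalen-2-yl on a saturated chain carbon bound to an amide-type nitrogen and a saturated chain carbon.

Among the measured compounds shown here, only one measured step touches the same place. Going from compound 1 to compound 3 gave a number 15 percentage points higher from compound 1 to compound 3 (beyond the scatter), a modest change for a swap at the same carbon. For the measured compounds named here, no measured step leads from naphthalen-2-yl to 4-chlorophenyl directly. Compound 2 also carries 4-chlorophenyl at this carbon and gives 139%, but its amide part differs from that of compound 4, so its number shows only that a high response is possible with this group.

Because compound 3 sits at 75% and compound 2 sits far higher, the expected step of a number 20 percentage points higher from compound 3 to compound 4 (beyond the scatter) is upward, though uncertain. Compound 4 is estimated at 95%, within 60% to 135%.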

Compound 4, largest response reached (reported as efficacy), in percent of the reference or control that the assay uses: 73%
The estimate for compound 4 lay 22 percentage points above the measured number; low and high end bracket the measured number.
By their numbers in this assay, from the lowest: compound 1; then compounds 4 and 3 (each within the scatter of the next); then compound 2.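

In this assay, 4-chlorophenyl in place of naphthalen-2-yl on the saturated chain carbon gives a number 2 percentage points lower from compound 3 to compound 4 (within the scatter), so at this place one six-membered aromatic ring serves as well as the two-ring group when the trifluoromethyl group is present on the amide side. The other two steps separate the two changes: trifluoromethyl in place of hydrogen on an aromatic carbon gives a number 66 percentage points lower from compound 2 to compound 4 (beyond the scatter), which is large and shows that the high response of compound 2 does not come from 4-chlorophenyl alone, while chloro in place of methyl on an aromatic carbon gives a number 13 percentage points higher from compound 1 to compound 4 (beyond the scatter), a modest shift. No evidence is available to explain why any of these changes alters the maximal response.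

From the compounds shown here alone, it remains open whether the large effect of trifluoromethyl would hold with naphthalen-2-yl or 4-methylphenyl on the chain carbon, since only the 4-chlorophenyl pair shows it. Going by these compounds, it is also open how a methoxy group or a fluorine in place of the chloro, or a pyridine ring in place of the phenyl ring, would fare at this position.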